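Aryl amide variation on the shared core: working notes

This account rests on a few compounds, and the source may have more. Where it says the series, first, only, none or still open, it means among the compounds named here.

Measured so far in an ADME assay on WI-38 cells (Homo sapiens) for antiproliferative activity, read by BrdU incorporation, with a stated time of 24 h; on this read-out higher numbers stand for weaker inhibition and lower numbers for stronger inhibition:
- compound 1 `O=C(CN1CCN(c2cc3c(cc2F)c(=O)c(C(=O)O)cn3C2CC2)CC1)Nc1ccccc1` — a limit of this assay, > 100000 nM
- compound 2 `COc1ccc(NC(=O)CN2CCN(c3cc4c(cc3F)c(=O)c(C(=O)O)cn4C3CC3)CC2)cc1` — a limit of this assay, > 100000 nM
- compound 3 `COc1cc(NC(=O)CN2CCN(c3cc4c(cc3F)c(=O)c(C(=O)O)cn4C3CC3)CC2)cc(OC)c1OC` — a limit of this assay, > 100000 nM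

Compound 3 stands at a limit only, and the other two values shown are limits as well (the limit of > 100000 nM in this assay, at which 3 of the 3 values shown sit). The steps among them cannot be sized: a step that the two limits leave unreadable from compound 1 to compound 2, a step that the two limits leave unreadable from compound 1 to compound 3 and a step that the two limits leave unreadable from compound 2 to compound 3. Nothing in the three compounds separates the phenyl, 4-methoxyphenyl and 3,4,5-trimethoxyphenyl amides from one another on this read-out.

Compound 4 `Cc1ccc(NC(=O)CN2CCN(c3cc4c(cc3F)c(=O)c(C(=O)O)cn4C3CC3)CC2)cc1` is not yet measured. It differs from compound 3 in one place: 4-methylphenyl in place of 3,4,5-trimethoxyphenyl on an amide-type nitrogen. All measured steps bear on this change, since each swaps the aryl group on the same amide-type nitrogen, and each is unreadable because every value sits at the limit (the limit of > 100000 nM in this assay, at which 3 of the 3 values shown sit). No direction can be expected from them; the plain expectation is another limit.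

Compound 4 is therefore estimated at 100000 nM in this assay, with a range from 40000 nM to 250000 nM, meaning an expected step of a number no higher from compound 3 to compound 4 (the limit leaves the size open).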

Compound 4, half-maximal inhibitory concentration: > 100000 nM
Compound 4: a limit, no number; the forecaster's own chance of this, stated with the estimate: 80%; the middle value lies on the limit itself.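

No step among compound 1, compound 2, compound 3 and compound 4 can be read in this assay, because every value is the same limit: the limit of > 100000 nM in this assay, at which 4 of the 4 values shown sit.

The compounds shown leave open whether any aryl group on the amide-type nitrogen gives a measurable inhibition on this read-out.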